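The source may report more compounds than this note shows. Statements on the series, on what has been measured and on what is new or still open speak of the compounds shown alone.

Working notes on the series. The shared core appears in compound 1 `Nc1cc(N)c2nc(-c3ccccc3)c(Oc3ccc(Cl)c(Cl)c3)nc2c1`, compound 2 `COc1ccc(CNc2nc3cc(N)cc(N)c3nc2-c2ccccc2)cc1OC`, compound 3 `Nc1cc(N)c2nc(-c3ccccc3)c(NCc3ccc(F)cc3)nc2c1` and the still unmeasured compound 4 `Nc1cc(N)c2nc(-c3ccccc3)c(Oc3ccc(F)cc3)nc2c1`. For the measured compounds named here, in a functional assay on HCT-15 cells (Homo sapiens) for inhibition, read by sulforhodamine B assay, with a stated time of 48 h (on this read-out lower numbers stand for stronger inhibition of growth and higher numbers for weaker inhibition of growth), compound 3 gives 19100 nM, the only resolved number in the set. For compound 1 the entry is a limit of the assay, < 100000 nM. For compound 2 the entry is likewise a limit of the assay, < 100000 nM. The change from compound 3 to compound 4 is 4-fluorophenoxy in place of (4-fluorobenzyl)amino on an aromatic carbon. The two measured steps that reach compound 3, a step that the limit leaves unreadable from compound 1 to compound 3 and a step that the limit leaves unreadable from compound 2 to compound 3, have no readable size because of the limit of < 100000 nM in this assay, at which 2 of the 3 values shown sit, so no direction can be taken from them. For compound 4 a value close to compound 3 is therefore expected, 25000 nM with a range of 6000 nM to 100000 nM. The estimated step of a 1.3-fold higher number from compound 3 to compound 4 (0.12 log units; within the scatter) is expected to stay within the scatter.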

Compound 4, concentration for total growth inhibition: < 100000 nM
Compound 4 was reported as a limit (the forecaster's own chance of this, stated with the estimate: 30%); the middle value lies beyond the limit too.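

No step to compound 4 from compound 3 or compound 1 can be read, because the entry for compound 4 is a limit: the limit of < 100000 nM in this assay, at which 3 of the 4 values shown sit.

The compounds shown leave open the size and direction of the change from (4-fluorobenzyl)amino to 4-fluorophenoxy.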